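Swapping the aryl group on the carbonyl: compound 3 to compound 4

A few compounds are considered here, and "the series" means these few. Any claim that something is new, unique, unknown or untested is made for them only; others in the source may bear on it.

Three compounds share a core built from a pyrazole linked to a trimethoxyphenyl or methoxyphenyl ring and to an unsaturated ketone. Compound 1 `COc1cc(-c2cc(/C=C/C(=O)c3ccc(N)cc3)[nH]n2)cc(OC)c1OC`, compound 2 `COc1ccc(-c2cc(/C=C/C(=O)c3ccc(OC)c(OC)c3)[nH]n2)cc1` and compound 3 `COc1cc(-c2cc(/C=C/C(=O)c3ccc(Cl)c(Cl)c3)[nH]n2)cc(OC)c1OC` were all tested in a functional assay on MDA-MB-435 cells (Homo sapiens) for cytotoxicity, read by sulforhodamine B assay, with a stated time of 48 h, tested at 0.01 uM; a lower number here means a stronger effect, a higher number a weaker effect of the compound at the concentration tested. Compound 1 gives 90%, compound 2 gives 97% and compound 3 gives 94%. All three numbers sit close together, so compound 3 cannot be told apart from either neighbour: the step of a number 4 percentage points higher from compound 1 to compound 3 (within the scatter) lies within the scatter, and the values of compound 3 and compound 2 differ by even less.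

Compound 4 `COc1ccc(C(=O)/C=C/c2cc(-c3cc(OC)c(OC)c(OC)c3)n[nH]2)cc1` has not yet been measured. It differs from compound 3 in one place: 4-methoxyphenyl in place of 3,4-dichlorophenyl on a carbonyl carbon. Among the compounds with values here, the only measured step touching this position is the one from compound 1 to compound 3, which stayed within the scatter when one aryl group was exchanged for another on the carbonyl carbon. Compound 2, which also carries a methoxy-bearing aryl group on its carbonyl carbon, shows a value in the same narrow band. On this basis no step beyond the scatter is expected in this assay for compound 4, whose value is estimated at 93% with a range from 82% to 103%. The expected step is therefore a number 1 percentage points lower from compound 3 to compound 4 (within the scatter).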

Compound 4, a percentage reported as activity, at one concentration (the size of the read-out at that concentration, not a potency): 99%
Estimate against measurement, compound 4: 6 percentage points below; the measured number falls inside the stated range.
By their numbers in this assay, from the lowest: compounds 1, 3, 2 and 4 (each within the scatter of the next).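

In this assay, replacing 3,4-dichlorophenyl with 4-methoxyphenyl on the carbonyl carbon gives a number 5 percentage points higher from compound 3 to compound 4 (within the scatter), so at this single low concentration the two groups cannot be told apart, even though they differ in their atoms and the entering group brings one hydrogen-bond acceptor where the leaving group has none. The comparison with the amino compound, where methoxy stands in place of amino on an aromatic carbon, gives a number 9 percentage points higher from compound 1 to compound 4 (within the scatter), and so this change cannot be read as having any effect either. Compounds 1, 3 and 4 share the trimethoxyphenyl part and now place three different aryl groups on the carbonyl carbon, and none of the steps among them lies beyond the scatter, so this position shows no measurable sensitivity to these three groups in this assay.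

Still open, on these data alone, is whether a carboxylic acid on this aryl ring, a longer chain in place of the methoxy group, or a higher test concentration would separate the compounds. Nothing measured here offers an explanation for this flat result.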